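Benzyl to phenoxy at the assay limit

The source may report more compounds than this note shows. Statements on the series, on what has been measured and on what is new or still open speak of the compounds shown alone.

Compound 1 `CCCCCn1c(=O)c(C(=O)Nc2cc([N+](=O)[O-])ccc2O)c(O)c2ccccc21`: > 10000 nM
Compound 2 `Cn1c(=O)c(C(=O)O)c(O)c2cc(Cc3ccccc3)ccc21`: > 10000 nM

Both entries are limits, not numbers, from a functional assay on HCT-116 cells (Homo sapiens) for cytotoxicity, read by MTT assay, with a stated time of 72 h; on this read-out higher numbers stand for lower toxicity in this test and lower numbers for higher toxicity in this test. Compound 2 gives only the limit > 10000 nM. So far, the record shows (the limit of > 10000 nM in this assay, at which 2 of the 2 values shown sit).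

Compound 3 `Cn1c(=O)c(C(=O)O)c(O)c2cc(Oc3ccccc3)ccc21` has phenoxy in place of benzyl on an aromatic carbon, (phenoxy in place of benzyl on an aromatic carbon). Going by the values given here, no measured step covers this change, so no step beyond the scatter is expected in this assay, in either direction. The estimated step that the limit leaves unreadable from compound 2 to compound 3 is therefore expected to be small. Compound 3 is expected to give about 15000 nM, with an estimated range of 7000 nM to 40000 nM.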

Compound 3, half-maximal cytotoxic concentration: > 10000 nM
Compound 3 ended at the assay's limit; the forecaster's own chance of this, stated with the estimate: 85%; the middle value does not contradict the limit.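

Compound 2 and compound 3 both stand only as limits in this assay, so no step can be read for phenoxy in place of benzyl. The compounds shown leave open whether the two groups differ at all in this assay.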